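The source may report more compounds than this note shows. Statements on the series, on what has been measured and on what is new or still open speak of the compounds shown alone.

Measured in an ADME assay on K562 cells (Homo sapiens) for cytotoxicity, with a stated time of 72 h; a lower number here means a stronger inhibitor, a higher number a weaker inhibitor:
- Compound 1 `COc1ccc(CNc2ncnc3c2ncn3C2CCCCO2)cc1OC` gives > 100000 nM (a limit)
- Compound 2 `COc1cc(CNc2ncnc3c2ncn3C2CCCCO2)cc(OC)c1` gives > 100000 nM (a limit)
- Compound 3 `COc1cc(CNc2ncnc3c2ncn3C2CCCCO2)cc(OC)c1OC` gives > 100000 nM (a limit)

Compound 3 has no exact number, only the limit of the assay. It shares that position with the other two compounds, and the overall picture is the limit of > 100000 nM in this assay, at which 3 of the 3 values shown sit (limits, not numbers). Two measured steps lead to compound 3, each placing a methoxy in place of hydrogen on an aromatic carbon. One is a step that the two limits leave unreadable from compound 1 to compound 3 and the other is a step that the two limits leave unreadable from compound 2 to compound 3 (neither has a size that can be used).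

Compound 4 `COc1cc(CNc2ncnc3c2ncn3C2CCCO2)cc(OC)c1OC` keeps the rest of compound 3 and changes one group: oxolan-2-yl in place of oxan-2-yl on an aromatic nitrogen. Neither measured step touches this group, so neither gives a size to carry over.

The expectation rests on compound 3, whose limit is > 100000 nM (again a limit). No step beyond the usual scatter is expected in this assay in either direction, and the expected change is a number no higher from compound 3 to compound 4 (the limit leaves the size open) (an estimate only). Compound 4 is estimated at 100000 nM (expected range 40000 nM to 250000 nM).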

Compound 4, half-maximal inhibitory concentration: > 100000 nM
Compound 4: no number, only a limit; the forecaster's own chance of this, stated with the estimate: 85%; the middle value lies on the limit itself.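

No size can be read for the step from compound 3 to compound 4 in this assay, where oxolan-2-yl replaces oxan-2-yl, because both results are limits and not numbers: the limit of > 100000 nM in this assay, at which 4 of the 4 values shown sit.

The compounds shown leave open whether any of these changes alters the value at all, since none of them gives an exact number.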